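Working notes: five-membered ring exchange, compound 2 to compound 4

This account rests on a few compounds, and the source may have more. Where it says the series, first, only, none or still open, it means among the compounds named here.

Measured so far in an assay on membranes from uterus for displacement of a labelled ligand from Angiotensin type II receptor (Sus scrofa), with a stated time of 1.5 h; on this read-out higher numbers stand for weaker inhibition and lower numbers for stronger inhibition:
compound 1 `CCCCOC(=O)NS(=O)(=O)c1sc(CC(C)C)cc1-c1ccc(Cc2nccs2)cc1` gives 3.2 nM
compound 2 `CCCCOC(=O)NS(=O)(=O)c1sc(CC(C)C)cc1-c1ccc(Cn2cccn2)cc1` gives 2.3 nM
compound 3 `CCCCOC(=O)NS(=O)(=O)c1sc(CC(C)C)cc1-c1ccc(C(=O)c2ncco2)cc1` gives 13.8 nM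

Compound 2 holds the lowest of the three numbers, but a 1.4-fold lower number from compound 1 to compound 2 (0.14 log units; within the scatter) lies within the scatter, so compound 1 and compound 2 cannot be ordered; only a 6.0-fold higher number from compound 2 to compound 3 (0.78 log units; beyond the scatter) separates compound 2 from compound 3.

Compound 4 `CCCCOC(=O)NS(=O)(=O)c1sc(CC(C)C)cc1-c1ccc(Cc2nnc(C(F)(F)F)o2)cc1` arises from compound 2 by 5-(trifluoromethyl)-1,3,4-oxadiazol-2-yl in place of 1H-pyrazol-1-yl on a saturated chain carbon bound to an aromatic carbon. For the measured compounds named here, the one step bearing directly on it is the ring exchange at the same place, a 1.4-fold lower number from compound 1 to compound 2 (0.14 log units; within the scatter), which was within the scatter; the larger steps of a 4.3-fold higher number from compound 1 to compound 3 (0.63 log units; beyond the scatter) and a 6.0-fold higher number from compound 2 to compound 3 (0.78 log units; beyond the scatter) also change the link and are less comparable. A small step is therefore expected, a 2.0-fold higher number from compound 2 to compound 4 (0.29 log units; within the scatter), with compound 4 estimated at 4.5 nM within 1.5 nM to 14 nM.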

Compound 4, inhibition constant: 328 nM
Beside the measured number, compound 4's estimate is 73-fold (1.86 log units) below it; measured number above the stated range.
By their numbers in this assay, from the lowest: compounds 2 and 1 (each within the scatter of the next); then compound 3; then compound 4.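

In this assay the place on a saturated chain carbon bound to an aromatic carbon proves sensitive to the ring it carries: 5-(trifluoromethyl)-1,3,4-oxadiazol-2-yl brings a 140-fold higher number from compound 2 to compound 4 (2.15 log units; beyond the scatter) and likewise a 100-fold higher number from compound 1 to compound 4 (2.01 log units; beyond the scatter) while the exchange between the two earlier rings stayed within the scatter. The series also shows a 24-fold higher number from compound 3 to compound 4 (1.38 log units; beyond the scatter) so a ring exchange alone at this place can outweigh a change of both link and ring. No measurement shown accounts for this step.

The compounds shown leave open whether the step follows the 1,3,4-oxadiazole ring itself or the trifluoromethyl group on it. A methyl group or a plain hydrogen in place of the trifluoromethyl would separate the two.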